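A few compounds are considered here, and "the series" means these few. Any claim that something is new, unique, unknown or untested is made for them only; others in the source may bear on it.

Measured so far in a functional assay (muscle tissue) with Cavia porcellus as the target; a higher number here means that more compound is needed for the effect, a lower number that less compound is needed
Compound 1 `COC(=O)C1=C(C)N=C(C)/C(=C(\O)OC)C1c1cccc(O)c1` gives 1000 nM
Compound 2 `COC(=O)C1=C(C)N=C(C)/C(=C(\O)OC)C1c1ccccc1C#N` gives 15.9 nM
Compound 3 `COC(=O)C1=C(C)N=C(C)/C(=C(\O)OC)C1c1ccccc1Br` gives 7.59 nM

Compound 3 has the lowest of these numbers, with a 2.1-fold lower number from compound 2 to compound 3 (0.32 log units; beyond the scatter) as a modest step beyond the scatter and a 130-fold lower number from compound 1 to compound 3 (2.12 log units; beyond the scatter) as a large one. Compound 4 `COC(=O)C1=C(C)N=C(C)/C(=C(\O)OC)C1c1cccc(C)c1` has not yet been measured. It carries 3-methylphenyl in place of 2-bromophenyl on a saturated ring carbon and is otherwise the same as compound 3. The large step to compound 3 bears most directly on this change, and a 63-fold lower number from compound 1 to compound 2 (1.80 log units; beyond the scatter) is also large. Among the compounds with values here, of the measured compounds, only compound 1 carries 3-hydroxyphenyl, and its 1000 nM is the one guide to leaving the 2-bromophenyl group for 3-methylphenyl. The change therefore runs against those large steps, and a clearly higher number is expected. Within the data shown here, no measured compound carries 3-methylphenyl, and compound 1 is a single case with a different group. Only part of that size is expected. The estimate means a 13-fold higher number from compound 3 to compound 4 (1.12 log units; beyond the scatter) as the expected move. The estimated value for compound 4 is 100 nM with an expected range from 25 nM to 400 nM.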

Compound 4, half-maximal effective concentration: 110 nM
For compound 4 the middle estimate is 1.1-fold (0.04 log units) below the measured one; the range from low to high includes it.
By their numbers in this assay, from the lowest: compound 3; then compound 2; then compound 4; then compound 1.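

In this assay, methyl in place of hydroxy on the same aromatic carbon gives a 9.1-fold lower number from compound 1 to compound 4 (0.96 log units; beyond the scatter), so the group carried at this place on the phenyl ring changes the number on its own, and the high number of compound 1 is tied in part to its hydroxy group. Even so, 3-methylphenyl does not match the two phenyl groups with a substituent at the 2 position: there is a 14-fold higher number from compound 3 to compound 4 (1.16 log units; beyond the scatter) and also a 6.9-fold higher number from compound 2 to compound 4 (0.84 log units; beyond the scatter), which places compound 4 between those compounds and compound 1. Among these four compounds, both 2-substituted phenyl groups therefore give lower numbers than both 3-substituted ones, and none goes against this, although the pattern rests on only two compounds on each side.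

Each of these two steps changes the substituent and where it sits on the phenyl ring together, so the compounds shown cannot separate the two, and 2-methylphenyl or 3-bromophenyl would be needed to do so. Nothing given here offers a measured explanation for any of these differences.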